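Methyl on the benzyl ring of a triazolothiadiazole series

The compounds below may be only part of what the source reports. "The series", "measured", "known", "first", "only" and "open" are said of these compounds alone.

Measured so far:
compound 1 `Cc1cccc(OCc2nn3c(Cn4nnc5ccccc54)nnc3s2)c1` — 50%
compound 2 `Fc1cccc(-c2nn3c(Cc4ccccc4)nnc3s2)c1` — 33%
compound 3 `Fc1cccc(-c2nn3c(-c4ccccc4)nnc3s2)c1` — 15%

In an assay for inhibition of histone-lysine N-methyltransferase, H3 lysine-79 specific (Homo sapiens), with stated times of 15 min and 120 min, tested at 50 uM (a higher number here means more inhibition at the concentration tested (going by the name of the read-out), a lower number less inhibition), compound 2 gives 33%, the second highest of the three numbers. Compound 1 lies closer to it, with 50% in this assay; compound 3, with 15%, lies furthest away. Among the compounds with values here, the one step between neighbours that differ in a single place is a number 18 percentage points lower from compound 2 to compound 3 (beyond the scatter), a modest drop.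

Compound 4 `Cc1ccccc1Cc1nnc2sc(-c3cccc(F)c3)nn12` has not been measured. It differs from compound 2 by methyl in place of hydrogen on an aromatic carbon, placed on an aromatic carbon of the six-membered carbon-only ring, ortho to a large group; cut one bond further out, the change reads phenyl to 2-methylphenyl.

Within the data shown here, no measured step bears on this change directly. Among the measured compounds shown here, the only step available, a number 18 percentage points lower from compound 2 to compound 3 (beyond the scatter), concerns the benzyl-to-phenyl exchange and leaves the benzyl ring of compound 2 intact, so it says nothing about a methyl on that ring. Compound 1 carries a methyl on a different ring, reached through a different linker, and its value cannot be tied to this change. In the absence of a bearing step, no shift beyond the scatter is expected in this assay; the step is estimated as a number 2 percentage points higher from compound 2 to compound 4 (within the scatter). Compound 4 is therefore expected to give about 35%, within a range of 18% to 52%.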

Compound 4, a percentage reported as inhibition, at one concentration (the size of the read-out at that concentration, not a potency): 27%
Compound 4: the middle estimate sits 8 percentage points above what was measured; the range from low to high includes it.
By their numbers in this assay, from the lowest: compound 3; then compounds 4 and 2 (each within the scatter of the next); then compound 1.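

In this assay, methyl in place of hydrogen on an aromatic carbon ortho to a large group gives a number 6 percentage points lower from compound 2 to compound 4 (within the scatter) and is the first change shown on the benzyl ring itself. Phenyl to 2-methylphenyl therefore adds one carbon at this position without a shift beyond the scatter, whereas removing the benzyl carbon gave a number 18 percentage points lower from compound 2 to compound 3 (beyond the scatter) and remains the only change here to move the read-out beyond the scatter. No independent measurement accompanies these numbers, so the result gives no explanation for how this position responds to methyl.

This single substitution leaves open how other groups would behave on the same carbon, such as chloro, methoxy, an amine or a carboxylic acid, and whether a larger group such as ethyl would stay within the scatter as well. Also open is whether the other carbons of the benzyl ring would respond in the same way, since the compounds shown carry a methyl at only this one place on that ring, and a single-concentration percentage gives no potency.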